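Trimming the biphenyl: from compound 3 to compound 4

The source may report more compounds than this note shows. Statements on the series, on what has been measured and on what is new or still open speak of the compounds shown alone.

Measured so far:
- compound 1, `CO[C@H]1O[C@H](COc2cccc3c2CCCC3)[C@@H](O)[C@H](O)[C@H]1Oc1ccc(OC2CCCCC2)cc1`, 3%
- compound 2, `CO[C@@H]1O[C@H](COc2ccc3c(c2)CCCC3)[C@@H](O)[C@H](O)[C@H]1Oc1ccc(OC2CCCCC2)cc1`, 14%
- compound 3, `CO[C@@H]1O[C@H](COc2ccc(-c3ccccc3)cc2)[C@@H](O)[C@H](O)[C@H]1Oc1ccc(OC2CCCCC2)cc1`, 51%

In a functional assay on MCF7 cells (Homo sapiens) for cytotoxicity, read by MTT assay, with a stated time of 48 h, tested at 20 uM (on this read-out lower numbers stand for less inhibition and higher numbers for more inhibition at the one concentration tested (going by the name of the read-out)), compound 3 gives the highest of the three numbers. Its nearest neighbour is compound 2, and the step of a number 37 percentage points higher from compound 2 to compound 3 (beyond the scatter) was large and beyond the scatter; compound 1 sits further away still, with the lowest number of the set. Compound 2 and compound 1 both carry a tetrahydronaphthalenyl group on the same oxygen and both give low numbers.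

Compound 4, `CO[C@@H]1O[C@H](COc2ccccc2)[C@@H](O)[C@H](O)[C@H]1Oc1ccc(OC2CCCCC2)cc1`, is the next compound. Its difference from compound 3 is hydrogen in place of phenyl on an aromatic carbon, so the 4-phenylphenyl group becomes a plain phenyl. Going by the values given here, no measured step removes a phenyl in this way, so the only guidance is indirect: the one large step, a number 37 percentage points higher from compound 2 to compound 3 (beyond the scatter), came with the 4-phenylphenyl group, and the two compounds without it give low numbers. Taking that away is therefore expected to move the number down, as a step of a number 31 percentage points lower from compound 3 to compound 4 (beyond the scatter), though the size of that drop is uncertain. Compound 4 is estimated at 20%, within the range 5% to 45%.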

Compound 4, a percentage reported as inhibition, at one concentration (the size of the read-out at that concentration, not a potency): -5%
Estimate against measurement, compound 4: 25 percentage points above, and the stated range ends above it.
By their numbers in this assay, from the lowest: compounds 4 and 1 (each within the scatter of the next); then compound 2; then compound 3.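

In this assay, the outer phenyl of the 4-phenylphenyl group turns out to carry most of the number at this position: taking it away gives a number 56 percentage points lower from compound 3 to compound 4 (beyond the scatter) and leaves compound 4 at -5%, so a single plain phenyl on this oxygen is not enough. The plain phenyl also falls short of the 1,2,3,4-tetrahydronaphthalen-6-yl group, with a number 19 percentage points lower from compound 2 to compound 4 (beyond the scatter), so the three compounds that differ only in this group form a clear ladder, with phenyl at the bottom, 1,2,3,4-tetrahydronaphthalen-6-yl in the middle and 4-phenylphenyl at the top. Nothing available explains why the outer ring makes such a difference to the read-out.

The compounds shown leave open whether the outer ring has to be a phenyl at all, or whether a pyridine ring, a morpholine or a butyl chain in its place would keep the number as high as in compound 3. Going by these compounds, each number also comes from one concentration, so how potent compound 3 really is remains unknown, as does whether the cyclohexyloxy group on the other side of the core plays any part.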